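Benzyloxy Addition in Two Chalcone Series on MCF7 Cells

This account rests on a few compounds, and the source may have more. Where it says the series, first, only, none or still open, it means among the compounds named here.

Measured compounds:
Compound 1, `Cc1cc(O)c(C(=O)/C=C/c2ccc(Br)cc2)c(-c2ccc(OCc3ccccc3)cc2)c1C(=O)/C=C/c1ccc(Br)cc1`: 30000 nM
Compound 2, `COc1ccc(/C=C/C(=O)c2c(C)cc(O)c(C(=O)/C=C/c3ccc(OC)c(OC)c3)c2-c2ccccc2)cc1OC`: "not active" (no number reported)
Compound 3, `Cc1cc(O)c(C(=O)/C=C/c2ccc(Br)cc2)c(-c2ccccc2)c1C(=O)/C=C/c1ccc(Br)cc1`: 10000 nM

Three compounds were tested in a functional assay on MCF7 cells (Homo sapiens) for cytotoxicity, read by MTT assay, with a stated time of 24 h; on this read-out lower numbers stand for stronger inhibition and higher numbers for weaker inhibition. Compound 3, `Cc1cc(O)c(C(=O)/C=C/c2ccc(Br)cc2)c(-c2ccccc2)c1C(=O)/C=C/c1ccc(Br)cc1`, gives 10000 nM, and compound 1 gives 30000 nM. The step between them, a 3.0-fold higher number from compound 3 to compound 1 (0.48 log units; beyond the scatter), corresponds to the change (benzyloxy in place of hydrogen on an aromatic carbon). Compound 2 is recorded in this assay only as "not active" (no number reported), without a number. The difference between the core of compound 2 and the core of compound 3 is not broken down here.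

Compound 4, `COc1ccc(/C=C/C(=O)c2c(C)cc(O)c(C(=O)/C=C/c3ccc(OC)c(OC)c3)c2-c2ccc(OCc3ccccc3)cc2)cc1OC`, is not yet measured. It stands to compound 2 as compound 1 stands to compound 3: the change is benzyloxy in place of hydrogen on an aromatic carbon, the same change as in the first pair. For the measured compounds named here, in the first pair that change gave a 3.0-fold higher number from compound 3 to compound 1 (0.48 log units; beyond the scatter), a weakening. Since compound 2 already shows "not active" (no number reported), compound 4 is expected to remain inactive or weak in this assay, and it is estimated at 60000 nM, within 20000 nM to 200000 nM.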

Compound 4, half-maximal inhibitory concentration: 30000 nM
Beside the measured number, compound 4's estimate is 2.0-fold (0.30 log units) above it, and the stated range covers the measured number.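

In this assay, for the compounds shown here, compound 4 gives 30000 nM while compound 2 is recorded only as "not active", without a number, so no step from compound 2 to compound 4 can be read. The compounds shown leave open how large the benzyloxy change is on the core of compound 2. Nothing given here offers an explanation for these results.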